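This account rests on a few compounds, and the source may have more. Where it says the series, first, only, none or still open, it means among the compounds named here.

Measured compounds:
compound 1 `Cc1cc(C)cc(Cc2ccc3c(NCCCNCc4ccco4)ccnc3c2)c1`: 23 10^-6 cm/s
compound 2 `COc1ccc(F)cc1CNCCCNc1ccnc2cc(Oc3ccc(C(C)(C)C)cc3)ccc12`: 317 10^-6 cm/s
compound 3 `CC(C)(C)c1ccc(Oc2ccc3c(NCCCNCc4ccco4)ccnc3c2)cc1`: 317 10^-6 cm/s

In an ADME assay for permeability, using PAMPA, with a stated time of 30 min, at pH 7.4 (a lower number here means that the compound crosses the layer more slowly, a higher number that the compound crosses the layer faster), compound 3 gives 317 10^-6 cm/s, level with compound 2 at the digits shown and together the highest of the three numbers. Among the compounds with values here, compound 1 gives 23 10^-6 cm/s, a clearly lower number than compound 3 and well beyond the scatter, while carrying a different group on the shared core in place of the aryl ether; no single step has been worked out for that pair, so only the two values themselves can be compared. Within the data shown here, the one step available, no change at the digits printed from compound 2 to compound 3 (within the scatter), concerns the group on the saturated chain carbon bound to an amine nitrogen and does not touch the aryl ether.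

Compound 4 `COc1cccc(Oc2ccc3c(NCCCNCc4ccco4)ccnc3c2)c1` is not yet measured. It differs from compound 3 by 3-methoxyphenyl in place of 4-(tert-butyl)phenyl on an oxygen on an aromatic ring. Among the measured compounds shown here, no measured step bears directly on this change; the only guide is that the sole substitution on the aryl ether in the set, between compound 1 and compound 3, moved the number a long way, whereas the chain-end step in this assay did not. For compound 4 a modest downward move, a 2.0-fold lower number from compound 3 to compound 4 (0.30 log units; within the scatter), is expected, well within the range between compound 1 and compound 3. Compound 4 is estimated at 160 10^-6 cm/s, expected between 50 10^-6 cm/s and 350 10^-6 cm/s.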

Compound 4, apparent permeability: 317 10^-6 cm/s
The estimate for compound 4 lay 2.0-fold (0.30 log units) below the measured number; low and high end bracket the measured number.
By their numbers in this assay, from the lowest: compound 1; then compounds 2, 3 and 4 (each within the scatter of the next).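

In this assay, 3-methoxyphenyl in place of 4-(tert-butyl)phenyl on an oxygen on an aromatic ring gives no change at the digits printed from compound 3 to compound 4 (within the scatter), so at this position an oxygen-bearing ring substituent and an all-carbon one cannot be told apart in this read-out. The second step, with 3-methoxyphenoxy in place of 3,5-dimethylbenzyl on an aromatic carbon, gives a 14-fold higher number from compound 1 to compound 4 (1.14 log units; beyond the scatter), which shows that the large gap to compound 1 is not tied to the tert-butyl group, as compound 3 alone left possible. No measured data on the compounds offer an explanation for either result.

The step from compound 1 changes the linking atom and the ring substituents together, so the compounds shown do not separate the benzyl-to-ether exchange from the change of substituents on the ring. Also open, on these data alone, is whether this position keeps its level with a ring carrying a carboxylic acid or an amine, since every aryl ether here carries only a tert-butyl or a methoxy group.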